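The source may report more compounds than this note shows. Statements on the series, on what has been measured and on what is new or still open speak of the compounds shown alone.

Series notes. Compound 3 `CC(C)CCN1C(=O)C(C2=NS(=O)(=O)c3cc(NS(C)(=O)=O)ccc3N2)=C(O)[C@H]2CCC[C@H]21` is the point of departure. In an ADME assay on Huh-7 cells (Homo sapiens) for cytotoxicity, with a stated time of 72 h (on this read-out higher numbers stand for lower toxicity in this test and lower numbers for higher toxicity in this test), compound 3 gives > 1000 nM, which is a limit of the assay and not a number. Compound 1 `CC(C)CCN1C(=O)C(C2=NS(=O)(=O)c3cc(NS(C)(=O)=O)ccc3N2)=C(O)C2CCCC21` has the same atoms and bonds, drawn without configuration at two ring stereocentres. In this assay compound 1 gives > 1000 nM, again a limit. The step that the two limits leave unreadable from compound 1 to compound 3 cannot be sized, due to the limit of > 1000 nM in this assay, at which 2 of the 3 values shown sit; the pair differs only in the fact that one of compounds 1 and 3 is drawn with a defined configuration and the other without, at the place where they differ. Compound 2 `CC(C)(C)CCN1C(=O)C(C2=NS(=O)(=O)c3cc(NS(C)(=O)=O)ccc3N2)=C(O)C2CCCCC21` is the third member. In this assay compound 2 gives > 33000 nM, also a limit, as stated in the limit of > 33000 nM in this assay, at which 1 of the 3 values shown sits. So compound 3 stands together with compound 1 at a limit, and none of the three values in this assay is a number.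

Compound 4 `CS(=O)(=O)Nc1ccc2c(c1)S(=O)(=O)N=C(C1=C(O)[C@H]3CCC[C@H]3N(Cc3ccc(C(F)(F)F)cc3)C1=O)N2` differs from compound 3 by 4-(trifluoromethyl)phenyl in place of isobutyl on a saturated chain carbon bound to an amide-type nitrogen in a ring. Going by the values given here, no measured step bears on this change: the only step in the set, from compound 1 to compound 3, is unreadable, and every value is a limit. The expectation for compound 4 therefore rests on the set as a whole, in which no compound has shown a measurable value. Compound 4 is expected to give 20000 nM in this assay, within 3000 nM to 100000 nM. The step that the limit leaves unreadable from compound 3 to compound 4 is expected to leave compound 4 in the same low-toxicity region, most likely again reported only as a limit.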

Compound 4, half-maximal cytotoxic concentration: > 33000 nM
Compound 4 ended at the assay's limit; the forecaster's own chance of this, stated with the estimate: 70%; middle value at least 1.6-fold (0.21 log units) away from the limit.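

In this assay compound 4 gives > 33000 nM, which is a limit and not a number. Compound 3 also sits at a limit, so the step between compound 3 and compound 4 cannot be read. The compounds shown leave open how 4-(trifluoromethyl)phenyl in place of isobutyl changes the half-maximal cytotoxic concentration, and where any of these compounds has a numerical value.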